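Shifting the methoxy and dropping the fluorine on the benzyl amide

The source may hold more compounds than are shown below. What is called first, only, known or untested is meant among the compounds shown, and "the series" means these compounds.

Compound 1 `COc1ccc(CNC(=O)c2nc(-c3ccc(F)cc3)n(CC[C@@H](O)C[C@@H](O)CC(=O)O)c2C2CC2)cc1F` is one of three closely related analogues sharing a common core and differing only in the aryl group on a saturated chain carbon bound to an amide-type nitrogen. In an assay on microsomes from liver for inhibition of 3-hydroxy-3-methylglutaryl-coenzyme A reductase (Rattus norvegicus), read by scintillation counting, with stated times of 0.5 h and 0.75 h (on this read-out higher numbers stand for weaker inhibition and lower numbers for stronger inhibition), compound 1 gives 3.7 nM, the highest number of the three. Compound 2 `Cc1ccc(CNC(=O)c2nc(-c3ccc(F)cc3)n(CC[C@@H](O)C[C@@H](O)CC(=O)O)c2C2CC2)cc1` gives 1.7 nM and compound 3 `COc1ccc(CNC(=O)c2nc(-c3ccc(F)cc3)n(CC[C@@H](O)C[C@@H](O)CC(=O)O)c2C2CC2)cc1` gives 1.2 nM. The steps from compound 1 are a 2.2-fold lower number from compound 1 to compound 2 (0.34 log units; beyond the scatter) and a 3.1-fold lower number from compound 1 to compound 3 (0.49 log units; beyond the scatter), while a 1.4-fold lower number from compound 2 to compound 3 (0.15 log units; within the scatter).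

Compound 4 `COc1cccc(CNC(=O)c2nc(-c3ccc(F)cc3)n(CC[C@@H](O)C[C@@H](O)CC(=O)O)c2C2CC2)c1` has not been measured. Relative to compound 1 the change is 3-methoxyphenyl in place of 3-fluoro-4-methoxyphenyl on a saturated chain carbon bound to an amide-type nitrogen. Going by the values given here, two measured steps bear on it: the loss of fluoro alone in a 3.1-fold lower number from compound 1 to compound 3 (0.49 log units; beyond the scatter) lowered the number beyond the scatter, and the exchange of methyl for methoxy in a 1.4-fold lower number from compound 2 to compound 3 (0.15 log units; within the scatter) stayed within it. Among the compounds with values here, no measured pair shows what relocating the methoxy does. A modest lowering is therefore expected, a 2.1-fold lower number from compound 1 to compound 4 (0.31 log units; beyond the scatter), with compound 4 estimated at 1.8 nM in this assay, between 0.7 nM and 5 nM.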

Compound 4, half-maximal inhibitory concentration: 1.2 nM
Compound 4: the middle estimate sits 1.5-fold (0.18 log units) above what was measured, and the stated range covers the measured number.
By their numbers in this assay, from the lowest: compounds 3, 4 and 2 (each within the scatter of the next); then compound 1.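

Relocating the methoxy is the one change the earlier compounds could not show, and in this assay it gives no change at the digits printed from compound 3 to compound 4 (within the scatter), so 3-methoxyphenyl and 4-methoxyphenyl cannot be told apart at this position. Replacing 4-methylphenyl with 3-methoxyphenyl gives a 1.4-fold lower number from compound 2 to compound 4 (0.15 log units; within the scatter), which leaves compounds 2, 3 and 4 together within the scatter. The full change gives a 3.1-fold lower number from compound 1 to compound 4 (0.49 log units; beyond the scatter), matching in printed size a 3.1-fold lower number from compound 1 to compound 3 (0.49 log units; beyond the scatter), and compound 1, the only one of the four with fluoro on this aryl group, stands apart from compounds 3 and 4.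

Nothing available explains why the fluoro-bearing compound 1 has the highest number. Open too, as far as these compounds go, is how this position would respond if an amine or a carboxylic acid took the place of the methoxy, or if a longer chain joined the aryl ring to the amide nitrogen.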